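From phenyl to 2,6-difluorophenyl on the aromatic nitrogen

A few compounds are considered here, and "the series" means these few. Any claim that something is new, unique, unknown or untested is made for them only; others in the source may bear on it.

In an ADME assay on HepG2 2.2.15 cells (Homo sapiens) for cytotoxicity (a lower number here means that less compound is tolerated, a higher number that more compound is tolerated), compound 1 (`Cn1c(=O)c(CCO)c(-c2ccccc2Cl)c2cc(Cl)ccc21`) gives 34000 nM while compound 2 (`O=c1c(CCO)c(-c2ccccc2Cl)c2cc(Cl)ccc2n1-c1ccccc1`) gives 26000 nM within the scatter of compound 1. Compound 3 (`O=c1c(CCO)c(-c2ccccc2Cl)c2cc(Cl)ccc2n1-c1c(F)cccc1F`) carries 2,6-difluorophenyl in place of phenyl on an aromatic nitrogen. Among the measured compounds shown here, the one measured step at that nitrogen (a 1.3-fold lower number from compound 1 to compound 2 (0.12 log units; within the scatter)) swaps methyl for phenyl, and no fluorinated compound has been measured yet. No step beyond the scatter is therefore expected in this assay, the estimated change being only a 1.0-fold lower number from compound 2 to compound 3 (0.02 log units; within the scatter) in size. Compound 3 is estimated at 25000 nM with an expected range from 11000 nM to 55000 nM overall.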

Compound 3, half-maximal cytotoxic concentration: > 2300000 nM
Compound 3: a limit, no number (the forecaster's own chance of this, stated with the estimate: 10%); at least 92-fold (1.96 log units) between middle value and limit.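

In this assay, this nitrogen proves sensitive to the substituent it carries: adding the two fluorines to the phenyl gives an at least 88-fold higher number from compound 2 to compound 3 (1.94 log units; beyond the scatter), and replacing the original methyl with 2,6-difluorophenyl gives an at least 67-fold higher number from compound 1 to compound 3 (1.83 log units; beyond the scatter). The earlier swap of methyl for phenyl had stayed within the scatter. Compound 3 stands as a limit, not a number: the limit of > 2300000 nM in this assay, at which 1 of the 3 values shown sits.

On these data alone, it remains open whether a single fluorine on the phenyl would produce the same shift, or whether chlorine in place of each fluorine would. Also open, as far as these compounds go, is whether the shift would persist with an amine in place of the 2-hydroxyethyl group.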